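Bromine-bearing ketone hydrazone on the shared triazolopyrimidine core

The compounds below may be only part of what the source reports. "The series", "measured", "known", "first", "only" and "open" are said of these compounds alone.

Measured compounds:
compound 1, `CCCSc1nc(N/N=C/c2ccc(C)cc2)c2nnn(Cc3ccccc3)c2n1`, > 64000 nM
compound 2, `C#CCSc1nc(N/N=C(\C)c2ccccc2O)c2nnn(Cc3ccccc3)c2n1`, 11300 nM

Of the compounds shown here, two have been measured in a functional assay on MCF7 cells (Homo sapiens) for antiproliferative activity, read by MTT assay, with a stated time of 72 h; on this read-out higher numbers stand for weaker inhibition and lower numbers for stronger inhibition. For compound 1 the value is only a limit of the assay, (the limit of > 64000 nM in this assay, at which 1 of the 2 values shown sits), so no number stands for it. Compound 2, which carries a different thioether and a different hydrazone on the same core, gives 11300 nM in this assay. Going by the values given here, no pair of measured compounds differs in a single place, so no measured step is available.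

Compound 3, `CCCSc1nc(N/N=C(\C)c2ccc(Br)cc2)c2nnn(Cc3ccccc3)c2n1`, differs from compound 1 in the hydrazone group: a group of 10 heavy atoms (8 carbon, 1 nitrogen, 1 bromine; one six-membered aromatic ring of carbon only) in place of a group of 9 heavy atoms (8 carbon, 1 nitrogen; one six-membered aromatic ring of carbon only), on a nitrogen on an aromatic ring.

Since only a limit of the assay is known for compound 1, the direction of the change can be judged solely against compound 2. The value of compound 2, 11300 nM, shows that a ketone hydrazone on this core can give a measurable number in this assay. Compound 3 is therefore expected to be measurable, with a step of an at least 3.2-fold lower number from compound 1 to compound 3 (0.50 log units; beyond the scatter) toward stronger inhibition. The estimate for compound 3 is 20000 nM, within a range of 5000 nM to 64000 nM, though a limit remains possible.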

Compound 3, half-maximal inhibitory concentration: 13000 nM
Beside the measured number, compound 3's estimate is 1.5-fold (0.19 log units) above it; the range from low to high includes it.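

In this assay, going by these compounds alone, exchanging the group on a nitrogen on an aromatic ring for the bromine-bearing group gives the first measured step: an at least 4.9-fold lower number from compound 1 to compound 3 (0.69 log units; beyond the scatter). With the rest of the molecule kept, a change in this one group is thus enough to bring a compound from a limit of the assay to a measured number, something compound 2 could not show, as it differs from compound 1 in both its thioether and its hydrazone. The true size of the step stays unknown because the value of compound 1 is a limit and not a number: the limit of > 64000 nM in this assay, at which 1 of the 3 values shown sits.

The exchange alters two things at once, placing a bromine on the aromatic ring where compound 1 has a methyl and adding a methyl on the hydrazone carbon, and the compounds shown do not tell which of the two carries the step. They also leave open whether a chlorine or a methoxy group in place of the bromine would give a similar number on this core, and whether the same exchange would have the same effect with another thioether chain.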